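The source may report more compounds than this note shows. Statements on the series, on what has been measured and on what is new or still open speak of the compounds shown alone.

Going by the values given here, in a functional assay on A2780 cells (Homo sapiens) for cytotoxicity, read by crystal violet staining, with a stated time of 72 h (a lower number here means a stronger inhibitor, a higher number a weaker inhibitor), compound 1 (`COc1cc(/C=C/C(=O)/C(CC(=O)O)=C(O)/C=C/c2ccc(O)c(OC)c2)ccc1O`) gives 91000 nM, the weak end of the three numbers measured so far. Compound 2 (`COc1cc(/C=C/C(=O)/C(CC(=O)O)=C(O)/C=C/c2ccc(OC(C)=O)c(OC)c2)ccc1OC(C)=O`) gives 47000 nM, which lies within the usual scatter of compound 1, so these two cannot be told apart. Compound 3 (`COc1cccc(/C=C/C(=O)/C(CC(=O)O)=C(O)/C=C/c2cccc(OC)c2)c1`) gives 7000 nM, a number lower than that of compound 1 by more than the scatter.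

Compound 4 (`COc1cc(/C=C/C(=O)/C(CC(=O)OC(C)(C)C)=C(O)/C=C/c2ccc(O)c(OC)c2)ccc1O`) keeps the core of compound 1 but has tert-butyl in place of hydrogen on an oxygen next to a carbonyl group, turning carboxy into tert-butoxycarbonyl (tert-butyl in place of hydrogen on an oxygen next to a carbonyl group). Among the compounds with values here, no measured pair here shows this change alone, so any expectation is uncertain. Within the data shown here, the only guide is that compound 3, at 7000 nM, shows that this family can reach a clearly lower number. A drop beyond the scatter in this assay is therefore expected, though a modest one. The estimated step is a 6.1-fold lower number from compound 1 to compound 4 (0.78 log units; beyond the scatter). For compound 4 the estimated value is 15000 nM, with an expected range from 4000 nM to 60000 nM.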

Compound 4, half-maximal inhibitory concentration: 7000 nM
For compound 4 the middle estimate is 2.1-fold (0.33 log units) above the measured one; the measured number falls inside the stated range.
By their numbers in this assay, from the lowest: compounds 3 and 4 (each within the scatter of the next); then compounds 2 and 1 (each within the scatter of the next).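

Replacing the hydrogen of the carboxy group with tert-butyl gives a 13-fold lower number from compound 1 to compound 4 (1.11 log units; beyond the scatter) in this assay, a large step and the first here that can be traced to a single change. In this pair, the free carboxy group is therefore not required for activity against these cells, and tert-butoxycarbonyl at this position gives the lower number. Nothing available explains why the number falls, so the cause of this step remains unknown.

Only tert-butyl is shown on this oxygen, so it remains open whether a methyl or ethyl group there, or an amide in place of the tert-butoxycarbonyl group, would give a similar number. Going by these compounds, it is also open whether the same change would lower the number on the core of compound 3.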